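The source may report more compounds than this note shows. Statements on the series, on what has been measured and on what is new or still open speak of the compounds shown alone.

Compound 2 `CC1(C)N=C(N)N=C(N)N1c1ccccc1C(F)(F)F` stands lowest of the two numbers in hand: in an assay for inhibition of Dihydrofolate reductase (Bos taurus), at pH 6.25 (a higher number here means a more potent compound, by a factor of ten per unit of this negative logarithm, a lower number a less potent compound), compound 2 gives 3.15, while compound 1 `CC1(C)N=C(N)N=C(N)N1c1ccccc1O` gives 3.86. For the measured compounds named here, the only measured step, a number 0.71 log units lower from compound 1 to compound 2 (beyond the scatter), shows that swapping the group on this aromatic carbon can move the read-out by a modest amount. Compound 3 `CC1(C)N=C(N)N=C(N)N1c1ccccc1I` carries iodo in place of trifluoromethyl on an aromatic carbon, the group sitting on an aromatic carbon of the six-membered ring of carbon only, ortho to a large group. Going by the values given here, no measured step exchanges trifluoromethyl for iodo, so the step from compound 1 to compound 2 bears on compound 3 only as a gauge of how much this position can change the number; its direction is not informative. A step near zero, or at most a small one in either direction, is therefore expected, a number 0.15 log units higher from compound 2 to compound 3 (within the scatter). The value estimated for compound 3 is 3.3, in a range from 2.7 to 4.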

Compound 3, logarithm of the reciprocal of the active concentration, log(1/C): 3.43
Compound 3: middle estimate off by 0.13 log units, on the low side; low and high end bracket the measured number.
By their numbers in this assay, from the lowest: compounds 2 and 3 (each within the scatter of the next); then compound 1.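

In this assay, iodo and trifluoromethyl on this aromatic carbon cannot be told apart: a number 0.28 log units higher from compound 2 to compound 3 (within the scatter) is a step inside the scatter, so this exchange of groups leaves the read-out unresolved. Hydroxy now stands apart from both groups, since a number 0.43 log units lower from compound 1 to compound 3 (beyond the scatter) joins a number 0.71 log units lower from compound 1 to compound 2 (beyond the scatter) as a second step beyond the scatter, and the gap between hydroxy and the other groups at this position is seen in both pairs rather than one. Nothing measured here accounts for this separation of compound 1 from compounds 2 and 3.

Going by these compounds, whether an amine or a methoxy group on this aromatic carbon would fall with compound 1 or with compounds 2 and 3 remains open. So does the read-out with plain hydrogen at this position on the shared core.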